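Trifluoromethyl step from compound 1 to compound 4

The compounds below may be only part of what the source reports. "The series", "measured", "known", "first", "only" and "open" are said of these compounds alone.

Measured in a functional assay on PBMC cells (Homo sapiens) for inhibition, read by HTRF, with stated times of 15 min and 24 h (on this read-out lower numbers stand for stronger inhibition and higher numbers for weaker inhibition), so far:
- compound 1 `O=C(Nc1ccc2c(c1)B(O)OC2)c1ccccc1F` gives > 10000 nM as a limit
- compound 2 `COc1ccccc1C(=O)Nc1ccc2c(c1)B(O)OC2` gives > 100000 nM as a limit
- compound 3 `O=C(Nc1ccc2c(c1)B(O)OC2)c1c(F)cccc1C(F)(F)F` gives 370 nM as a number

Compound 1 stands at > 10000 nM, which is a limit. Compound 4 `O=C(Nc1ccc2c(c1)B(O)OC2)c1ccc(C(F)(F)F)cc1F` carries one change from compound 1: trifluoromethyl in place of hydrogen on an aromatic carbon. The closest evidence is the same exchange on another aromatic carbon, which gave an at least 27-fold lower number from compound 1 to compound 3 (1.43 log units; beyond the scatter). The methoxy step that the two limits leave unreadable from compound 1 to compound 2 does not bear on this change. The place differs, and only part of the compound 3 step is expected to carry over. In this assay a lower number is expected, with an at least 5.0-fold lower number from compound 1 to compound 4 (0.69 log units; beyond the scatter) as the estimated step. For compound 4 the estimated value is 2000 nM, with an expected range from 350 nM to 12000 nM.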

Compound 4, half-maximal inhibitory concentration: > 100000 nM
Compound 4 was reported as a limit; the forecaster's own chance of this, stated with the estimate: 25%; middle value at least 50-fold (1.69 log units) from the limit.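

For the compounds shown here, compound 1 and compound 4 are both reported only as limits, and no step between them can be read. The compounds shown leave open how trifluoromethyl at this place shifts the number in this assay.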